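This account rests on a few compounds, and the source may have more. Where it says the series, first, only, none or still open, it means among the compounds named here.

Measured so far:
Compound 1, `Cc1ccc(CSc2cc(Cl)c(C)cc2S(=O)(=O)/N=C(\N)n2nccc2-c2ccccc2)cc1`: in a functional assay on HCT-116 cells (Homo sapiens) for cytotoxicity, read by MTT assay, with a stated time of 72 h (on this read-out higher numbers stand for weaker inhibition and lower numbers for stronger inhibition), compound 1 gives 14000 nM.
Compound 2, `Cc1cc(S(=O)(=O)/N=C(\N)n2nccc2-c2ccccc2)c(SCc2cccc(C(F)(F)F)c2)cc1Cl`: in this assay compound 2 gives 14000 nM.

On the numbers shown, compound 2 stands level with compound 1 at the digits given; its only neighbour among the measured compounds is compound 1, and the step of no change at the digits printed from compound 1 to compound 2 (within the scatter), in which 3-(trifluoromethyl)phenyl replaced 4-methylphenyl on a saturated chain carbon bound to a sulfur, lies within the scatter.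

The compound still to be measured is compound 3, `Cc1cc(S(=O)(=O)/N=C(\N)n2nccc2-c2ccccc2)c(SCc2ccccc2C(F)(F)F)cc1Cl`. Its difference from compound 2 is 2-(trifluoromethyl)phenyl in place of 3-(trifluoromethyl)phenyl on a saturated chain carbon bound to a sulfur. The two hold the same atoms, joined differently: 3-(trifluoromethyl)phenyl leaves and 2-(trifluoromethyl)phenyl enters, on a saturated chain carbon bound to a sulfur.

For the measured compounds named here, only one measured step touches this carbon, and it showed no change beyond the scatter when the group there was exchanged. Compound 3 is therefore expected to remain near compound 2 in this assay. The step this estimate implies, no change at the digits printed from compound 2 to compound 3 (within the scatter), is expected to fall within the scatter. Compound 3 is estimated at 14000 nM, with a range from 7000 nM to 28000 nM.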

Compound 3, half-maximal inhibitory concentration: 16000 nM
Compound 3: middle estimate off by 1.1-fold (0.06 log units), on the low side; the measured number falls inside the stated range.
By their numbers in this assay, from the lowest: compounds 1, 2 and 3 (each within the scatter of the next).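

Exchanging 3-(trifluoromethyl)phenyl for 2-(trifluoromethyl)phenyl on a saturated chain carbon bound to a sulfur joins the same atoms differently, and in this assay this gives a 1.1-fold higher number from compound 2 to compound 3 (0.06 log units; within the scatter), so these two arrangements of the trifluoromethyl group cannot be told apart on this read-out. Exchanging 4-methylphenyl for 2-(trifluoromethyl)phenyl at the same carbon gives a 1.1-fold higher number from compound 1 to compound 3 (0.06 log units; within the scatter), which means that all three substituted phenyl groups shown there now read alike within the scatter, whichever of the two trifluoromethyl arrangements is compared with the 4-methylphenyl compound. No measurement accompanies these values that could say why the three compounds read alike.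

The compounds shown leave open whether a group with no aromatic ring at this carbon, such as cyclohexyl, a longer alkyl chain, or a chain ending in an amine or a carboxylic acid, would read differently in this assay. Every step shown falls on this one carbon, and what a change elsewhere on the shared core would do remains open too.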